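Propargyl for Methyl on a Second Core

The source may report more compounds than this note shows. Statements on the series, on what has been measured and on what is new or still open speak of the compounds shown alone.

Measured compounds:
compound 1 `Cc1nc(O)c2cc(CN(C)c3ccc(C(=O)N[C@@H](CCC(=O)O)C(=O)N(C)[C@@H](CCC(=O)O)C(=O)O)c(F)c3)ccc2n1` — 9200 nM
compound 2 `C#CCN(Cc1cc2c(O)nc(C)nc2cc1C)c1ccc(C(=O)N[C@@H](CCC(=O)O)C(=O)N(C)[C@@H](CCC(=O)O)C(=O)O)cc1` — 2000 nM
compound 3 `Cc1nc(O)c2cc(CN(C)c3ccc(C(=O)N[C@@H](CCC(=O)O)C(=O)N(C)[C@@H](CCC(=O)O)C(=O)O)cc3)c(C)cc2n1` — 4000 nM

All three were tested in a functional assay for inhibition, with Mus musculus as the target; a higher number here means a weaker inhibitor, a lower number a stronger inhibitor. Compound 1 shows the highest number of the set, and its step to compound 3 lies beyond the scatter, as does its step to compound 2. How the core of compound 1 differs from that of compound 3 is not broken down here.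

Compound 2 differs from compound 3 in one place, (ethynyl in place of hydrogen on a saturated chain carbon bound to a nitrogen on an aromatic ring), and this gave a 2.0-fold lower number from compound 3 to compound 2 (0.30 log units; within the scatter). Compound 4 `C#CCN(Cc1ccc2nc(C)nc(O)c2c1)c1ccc(C(=O)N[C@@H](CCC(=O)O)C(=O)N(C)[C@@H](CCC(=O)O)C(=O)O)c(F)c1` carries the same change made on compound 1: ethynyl in place of hydrogen on a saturated chain carbon bound to a nitrogen on an aromatic ring. Within the data shown here, a step of similar size is expected from compound 1 to compound 4, namely a 2.0-fold lower number from compound 1 to compound 4 (0.30 log units; within the scatter), because a 2.0-fold lower number from compound 3 to compound 2 (0.30 log units; within the scatter) is the only measured precedent for this change and is itself within the scatter. Compound 4 is therefore estimated at 4600 nM, with an expected range from 2000 nM to 10000 nM.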

Compound 4, half-maximal inhibitory concentration: 2600 nM
For compound 4 the middle estimate is 1.8-fold (0.25 log units) above the measured one, and the stated range covers the measured number.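

In this assay, methyl to propargyl on the core of compound 1 gave a 3.5-fold lower number from compound 1 to compound 4 (0.55 log units; beyond the scatter). Set beside the earlier step on the other core, this shows that the change carried over with no size difference that can be told apart: the same change on two cores in this assay, a 2.0-fold lower number (0.30 log units; within the scatter) from compound 3 to compound 2 and a 3.5-fold lower number (0.55 log units; beyond the scatter) from compound 1 to compound 4, 1.8-fold (0.25 log units) apart, within the scatter of two such steps. It does not show a fixed step size, since only two pairs are shown, and only the step on the core of compound 1 lies beyond the scatter.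

The compounds shown leave open whether the step would hold on further cores. They also leave open whether an ethyl or a cyanomethyl group would do the same as propargyl in that place.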